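Swapping cyano for butoxy in compound 1

This account rests on a few compounds, and the source may have more. Where it says the series, first, only, none or still open, it means among the compounds named here.

Measured in a functional assay on MT4 cells (Homo sapiens) for cytotoxicity, read by MTT assay; on this read-out higher numbers stand for lower toxicity in this test and lower numbers for higher toxicity in this test:
compound 1 `Cc1c(O)nc(SCc2ccc(C#N)cc2)nc1Cc1c(Cl)cccc1Cl`: > 60000 nM
compound 2 `COc1cc(CSc2nc(O)c(C)c(Cc3c(F)cccc3F)n2)cc(OC)c1`: > 60000 nM

Compound 1 gives only a limit in this assay, > 60000 nM, and not a number. Compound 2 likewise gives only a limit, > 60000 nM. Together, the data show (the limit of > 60000 nM in this assay, at which 2 of the 2 values shown sit).

Compound 3 `CCCCOc1ccc(CSc2nc(O)c(C)c(Cc3c(Cl)cccc3Cl)n2)cc1` differs from compound 1 in one place, with butoxy in place of cyano on an aromatic carbon, para to a large group (butoxy in place of cyano on an aromatic carbon). For the measured compounds named here, no measured step shows what such a change does in this assay. A modest move toward lower numbers, meaning higher toxicity in this test, is therefore expected, and another limit would be no surprise. The expected step is an at least 1.3-fold lower number from compound 1 to compound 3 (0.12 log units; that floor lies within the scatter). Compound 3 is estimated at 45000 nM, with an expected range from 15000 nM to 80000 nM.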

Compound 3, half-maximal cytotoxic concentration: 3100 nM
Estimate against measurement, compound 3: 15-fold (1.16 log units) above, outside the stated range (below it).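

In this assay, the aromatic carbon para to a large group proves able to shift the read-out toward higher toxicity in this test: butoxy in place of cyano gives (an at least 19-fold lower number from compound 1 to compound 3 (1.28 log units; beyond the scatter)). Compound 1 gives > 60000 nM and this is a limit, not a number, so the size of the step is known only from one side. Compound 3 is the only compound shown that gives a number and not a limit: (the limit of > 60000 nM in this assay, at which 2 of the 3 values shown sit).

The compounds shown leave open whether the shift goes with the butoxy chain itself or with the loss of cyano, and a shorter methoxy or a longer hexyloxy chain on the same carbon would speak to that. Also open, going by these compounds, is how an amine or a carboxylic acid at this place would read in this assay on the core of compound 1.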